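Swapping a sulfonyl substituent for an isopropylamino group

A few compounds are considered here, and "the series" means these few. Any claim that something is new, unique, unknown or untested is made for them only; others in the source may bear on it.

Compound 1 `CC(C)S(=O)(=O)c1ccc(S(=O)(=O)N2CCC[C@@H](C(=O)N3CCC(F)(F)CC3)C2)cc1` gives 50 nM in a functional assay on BXPC-3 cells (Homo sapiens) for inhibition, read by MTT assay, with a stated time of 7 days; on this read-out lower numbers stand for stronger inhibition and higher numbers for weaker inhibition. Going by the values given here, compound 2 `CC(C)CS(=O)(=O)c1ccc(S(=O)(=O)N2CCC[C@@H](C(=O)N3CCC(F)(F)CC3)C2)cc1` gives 311 nM, the higher of the two numbers; the change a 6.2-fold higher number from compound 1 to compound 2 (0.79 log units; beyond the scatter) is the only measured step here. Compound 3 `CC(C)NS(=O)(=O)c1ccc(S(=O)(=O)N2CCC[C@@H](C(=O)N3CCC(F)(F)CC3)C2)cc1` carries isopropylamino in place of isobutyl on a sulfonyl sulfur. Among the compounds with values here, the one measured step bears on this position only indirectly, since it replaced one chain with another while here a nitrogen-bearing group enters; no measured pair covers such a swap. Compound 3 is therefore expected to land between the two measured values, a step of a 2.4-fold lower number from compound 2 to compound 3 (0.38 log units; beyond the scatter), at an estimated 130 nM (range 30 nM to 550 nM).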

Compound 3, half-maximal inhibitory concentration: 470 nM
Compound 3: the middle estimate sits 3.6-fold (0.56 log units) below what was measured, and the stated range covers the measured number.
By their numbers in this assay, from the lowest: compound 1; then compounds 2 and 3 (each within the scatter of the next).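

Isopropylamino in place of isobutyl on the sulfonyl sulfur gives a 1.5-fold higher number from compound 2 to compound 3 (0.18 log units; within the scatter) and so does not separate these two compounds, even though a nitrogen has entered. Isopropylamino in place of isopropyl gives a 9.4-fold higher number from compound 1 to compound 3 (0.97 log units; beyond the scatter) and so leaves compound 1 apart from both others. Nothing available offers a reason for either result.

Still open, on these data alone, is whether a shorter chain such as methyl, a ring such as cyclopropyl, or an unsubstituted amine on the sulfonyl sulfur would stand with compound 1 or with the other two.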